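Methoxy added to the shared core

The source may report more compounds than this note shows. Statements on the series, on what has been measured and on what is new or still open speak of the compounds shown alone.

Compound 2 `COc1cc(OC)c2sc(-c3ccc(N/C=C\C(=O)c4cc(OC)c(OC)c(OC)c4)cc3)nc2c1` gives 17800 nM in a functional assay on HeLa cells (Homo sapiens) for antiproliferative activity, read by sulforhodamine B assay, with a stated time of 48 h (a higher number here means a weaker inhibitor, a lower number a stronger inhibitor), and compound 1 `COc1cc(OC)c2sc(-c3ccc(N/C=C\C(=O)c4ccc(OC)c(O)c4)cc3)nc2c1` gives 12100 nM in the same read-out, so the two stand level. Among the compounds with values here, the only measured step is a 1.5-fold higher number from compound 1 to compound 2 (0.17 log units; within the scatter) and lies within the scatter. It changes the group on a carbonyl carbon and leaves the shared core untouched. Compound 3 `COc1cc(C(=O)/C=C\Nc2ccc(-c3nc4cc(OC)c(OC)c(OC)c4s3)cc2)cc(OC)c1OC` carries methoxy in place of hydrogen on an aromatic carbon on that core: methoxy in place of hydrogen on an aromatic carbon, ortho to two methoxy groups. Within the data shown here, no measured step covers this place, so the guide is weak and no shift beyond the scatter is expected. The expected step is a 1.2-fold lower number from compound 2 to compound 3 (0.07 log units; within the scatter) and no more. The estimate for compound 3 is 15000 nM (range 6000 nM to 38000 nM).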

Compound 3, half-maximal inhibitory concentration: 5300 nM
Beside the measured number, compound 3's estimate is 2.8-fold (0.45 log units) above it; measured number below the stated range.
By their numbers in this assay, from the lowest: compound 3; then compounds 1 and 2 (each within the scatter of the next).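

Methoxy in place of hydrogen on an aromatic carbon, ortho to two methoxy groups, gives a 3.4-fold lower number from compound 2 to compound 3 (0.53 log units; beyond the scatter) in this assay. Within the data shown here, this is the first step beyond the scatter, and it shows that this position on the shared core, unlike the carbonyl-side change, can move the number. Nothing measured here accounts for the shift.

As far as these compounds go, whether the shift is specific to methoxy remains open, as a fluorine, an amine or a longer alkoxy chain at this position would test. Also open, from the compounds shown here alone, is whether it carries over to the 3-hydroxy-4-methoxyphenyl partner.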